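The compounds below may be only part of what the source reports. "The series", "measured", "known", "first", "only" and "open" are said of these compounds alone.

Compound 1, with the structure `Cc1cc(NC(=O)c2cc(C(F)(F)F)cc(C(F)(F)F)c2)ccc1NS(C)(=O)=O`, is tested in an ADME assay on RAW264.7 cells (Mus musculus) for cytotoxicity, read by MTT assay, with a stated time of 48 h; a lower number here means a stronger inhibitor, a higher number a weaker inhibitor. For compound 1 this assay reports only a limit, > 250000 nM, not a number. Compound 2, with the structure `CCS(=O)(=O)Nc1ccc(NC(=O)c2cc(C(F)(F)F)cc(C(F)(F)F)c2)cc1C`, differs from compound 1 by methyl in place of hydrogen on a saturated chain carbon bound to a sulfonyl sulfur. In this assay compound 2 gives 124000 nM, which makes the step of an at least 2.0-fold lower number from compound 1 to compound 2 (0.30 log units; that floor lies within the scatter). This step rests on the limit of compound 1 shown by the limit of > 250000 nM in this assay, at which 1 of the 3 values shown sits, so its true size is not pinned down.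

Compound 3, with the structure `CS(=O)(=O)Nc1ccc(NC(=O)c2ccc(Cl)cc2)cc1Cl`, has a different core, and the difference between the two cores is not broken down here. In this assay compound 3 gives 79900 nM, a value that sits within the usual scatter of compound 2.

Compound 4, with the structure `CCS(=O)(=O)Nc1ccc(NC(=O)c2ccc(Cl)cc2)cc1Cl`, is not yet measured and differs from compound 3 by methyl in place of hydrogen on a saturated chain carbon bound to a sulfonyl sulfur, the same change that separates compound 1 from compound 2. Because the earlier step of an at least 2.0-fold lower number from compound 1 to compound 2 (0.30 log units; that floor lies within the scatter) is only a floor set by a limit, a small change is expected here, estimated at a 1.3-fold lower number from compound 3 to compound 4 (0.12 log units; within the scatter). Compound 4 is therefore expected to give about 60000 nM, with a likely range of 25000 nM to 150000 nM.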

Compound 4, half-maximal inhibitory concentration: > 250000 nM
Compound 4: no number, only a limit; the forecaster's own chance of this, stated with the estimate: 5%; middle value at least 4.1-fold (0.61 log units) away from the limit.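

On the core of compound 3, going from methylsulfonyl to ethylsulfonyl gives an at least 3.1-fold higher number from compound 3 to compound 4 (0.49 log units; beyond the scatter) in this assay, so this change does not move the number the same way on the two cores: the same change on two cores in this assay, an at least 2.0-fold lower number (0.30 log units; that floor lies within the scatter) from compound 1 to compound 2 and an at least 3.1-fold higher number (0.49 log units; beyond the scatter) from compound 3 to compound 4, at least 6.3-fold (0.79 log units) apart, beyond the scatter of two such steps

Compound 4 reports a limit, > 250000 nM, not a number. Both steps are therefore only floors, their true sizes stay unknown, and nothing here shows why the direction differs between the two cores: the limit of > 250000 nM in this assay, at which 2 of the 4 values shown sit.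

The compounds shown leave open how a longer chain such as propylsulfonyl would read on either core, and whether a sulfonyl group carrying an amine or a carboxylic acid would follow the same course. Also open, going by these compounds, is which difference between the two cores goes with the change in direction, a question that a compound combining parts of both cores could help to settle.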